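The source may hold more compounds than are shown below. What is called first, only, known or untested is meant among the compounds shown, and "the series" means these compounds.

Series notes. Compound 1 `O=C(/C=C/c1cccnc1)c1nc2ccccc2[nH]1` and compound 2 `OC(/C=C/c1cccc(Cl)c1)c1nc2ccccc2[nH]1` share a core. In a functional assay on MCF7 cells (Homo sapiens) for antiproliferative activity, read by MTT assay, with a stated time of 48 h (on this read-out higher numbers stand for weaker inhibition and lower numbers for stronger inhibition), compound 1 gives 21700 nM. Compound 2 returns only a limit of the assay, > 100000 nM, and so sits at the limit of > 100000 nM in this assay, at which 1 of the 2 values shown sits; no number for it is known. Compound 3 `COc1cccc(/C=C/C(O)c2nc3ccccc3[nH]2)c1` is the next member and differs from compound 2 by methoxy in place of chloro on an aromatic carbon. Among the measured compounds shown here, with compound 2 at a limit, no measured step exists here, and the change is expected to move this assay little, if at all, beyond the scatter. Compound 3 is therefore estimated at 120000 nM, within 30000 nM to 500000 nM, with a fair chance that only a limit is again reported. The expected step is a step that the limit leaves unreadable from compound 2 to compound 3.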

Compound 3, half-maximal inhibitory concentration: > 100000 nM
Compound 3 gave a limit, no number; the forecaster's own chance of this, stated with the estimate: 65%; the middle value does not contradict the limit.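

No step from compound 2 to compound 3 can be read in this assay, where both give only a limit: the limit of > 100000 nM in this assay, at which 2 of the 3 values shown sit.

The compounds shown leave open whether methoxy in place of chloro on an aromatic carbon changes the read-out at all.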